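The compounds below may be only part of what the source reports. "The series", "measured", "known", "first", "only" and "open" are said of these compounds alone.

Among the compounds with values here, in an ADME assay on MT4 cells (Homo sapiens) for cytotoxicity, read by MTT assay (on this read-out lower numbers stand for higher toxicity in this test and higher numbers for lower toxicity in this test), compound 1 `Cc1ccc(CC2C(=O)N(O)C(=O)c3ccccc32)cc1` gives 5500 nM, the lower of the two numbers measured so far. Within the data shown here, the only other measured compound, compound 2 `CC(C)C1C(=O)N(O)C(=O)c2ccccc21`, gives 123000 nM, and this gap lies beyond the usual scatter. Compound 3 `CC1C(=O)N(O)C(=O)c2ccccc21` has not yet been measured. Its structure departs from that of compound 1 in a single place: hydrogen in place of 4-methylphenyl on a saturated chain carbon bound to a saturated ring carbon. In other words, the 4-methylphenyl leaves and a hydrogen takes its place. Among the measured compounds shown here, no measured pair differs in only one place, so there is no direct precedent for the size of this step. Compound 2 also lacks the 4-methylphenyl and stands at 123000 nM, so a large rise, beyond the scatter, is expected. The estimated step is a 22-fold higher number from compound 1 to compound 3 (1.34 log units; beyond the scatter). Compound 3 is expected to give about 120000 nM, within an estimated range of 40000 nM to 350000 nM.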

Compound 3, half-maximal cytotoxic concentration: 250000 nM
Estimate against measurement, compound 3: 2.1-fold (0.32 log units) below; low and high end bracket the measured number.
By their numbers in this assay, from the lowest: compound 1; then compound 2; then compound 3.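

In this assay, the 4-methylphenyl on the saturated chain carbon now has a measured effect of its own: replacing it with hydrogen gives a 45-fold higher number from compound 1 to compound 3 (1.66 log units; beyond the scatter), a large move towards lower toxicity in this test. A much shorter change at the saturated ring carbon, methyl in place of isopropyl, gives only a modest 2.0-fold higher number from compound 2 to compound 3 (0.31 log units; beyond the scatter), so the two changes at this part of the molecule differ clearly in size. Nothing measured here explains either step.

The groups shown at this ring carbon contain only carbon and hydrogen, so it remains open how an amine or a carboxylic acid there would behave. It is also unclear whether a phenyl without its methyl would retain the low number of compound 1.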